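The source may hold more compounds than are shown below. What is called first, only, known or untested is meant among the compounds shown, and "the series" means these compounds.

In a functional assay on SNB-75 cells (Homo sapiens) for inhibition, read by sulforhodamine B assay, with a stated time of 48 h (a higher number here means a weaker inhibitor of growth, a lower number a stronger inhibitor of growth), compound 1 `Cc1ccc(NC(=O)/C=C/c2ccccc2)c(C(N)=O)c1` gives 3180 nM and compound 2 `NC(=O)c1cc(Br)ccc1NC(=O)/C=C/c1ccccc1` gives 2070 nM, which places the two within the scatter of each other. Compound 3 `NC(=O)c1cc(I)ccc1NC(=O)/C=C/c1ccccc1` differs from compound 2 by one change: iodo in place of bromo on an aromatic carbon. Among the measured compounds shown here, the only measured step that bears on this is a 1.5-fold lower number from compound 1 to compound 2 (0.19 log units; within the scatter), a swap on the same aromatic carbon. For the measured compounds named here, with only that step to go on, no change beyond the scatter is expected in this assay. The estimated step is a 1.1-fold lower number from compound 2 to compound 3 (0.04 log units; within the scatter). Compound 3 is expected at 1900 nM, within an estimated range of 900 nM to 4000 nM.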

Compound 3, concentration for 50% growth inhibition: 245 nM
Compound 3: middle estimate off by 7.8-fold (0.89 log units), on the high side, outside the stated range (below it).
By their numbers in this assay, from the lowest: compound 3; then compounds 2 and 1 (each within the scatter of the next).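

On this aromatic carbon, para to a large group, the identity of the substituent does matter in this assay: iodo in place of bromo gives an 8.4-fold lower number from compound 2 to compound 3 (0.93 log units; beyond the scatter), whereas the earlier swap of methyl for bromo stayed within the scatter. Iodo in place of methyl gives a 13-fold lower number from compound 1 to compound 3 (1.11 log units; beyond the scatter), so among these three compounds only iodo stands apart. Nothing available bears on the cause of this difference. On these data alone, whether an amine, a nitrile or a trifluoromethyl group on this carbon would match iodo remains open, as does whether the iodo result holds in other cell lines.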